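A few compounds are considered here, and "the series" means these few. Any claim that something is new, unique, unknown or untested is made for them only; others in the source may bear on it.

Measured so far in a functional assay on CHO cells for agonist activity at Free fatty acid receptor 1 (Homo sapiens), read by FLIPR, with a stated time of 90 s, in the presence of a further agent that is not named here; a lower number here means that less compound is needed, a higher number that more compound is needed for the effect:
- compound 1 `Cc1cccc(C)c1-c1cccc(COc2ccc3c(c2)OCC3CC(=O)O)c1`: 27 nM
- compound 2 `O=C(O)CC1COc2cc(OCc3cccc(-c4csc5ccccc45)c3)ccc21`: 39 nM

Both compounds share one core, an acid-bearing bicyclic unit linked through an oxygen to a benzyl group that carries an aromatic substituent. Compound 1 carries 2,6-dimethylphenyl there and gives 27 nM in this assay. Compound 2 carries 1-benzothiophen-3-yl instead and gives 39 nM. The only measured step, a 1.4-fold higher number from compound 1 to compound 2 (0.16 log units; within the scatter), lies within the scatter, so compound 2 cannot be told apart from compound 1 on the numbers shown: it simply stands alongside it.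

Compound 3 `O=C(O)CC1COc2cc(OCc3cccc(-c4ccc5sccc5c4)c3)ccc21` differs from compound 2 only in the way the same atoms are joined: 1-benzothiophen-5-yl in place of 1-benzothiophen-3-yl on an aromatic carbon. Among the measured compounds shown here, no measured step bears directly on moving the point of attachment within a benzothiophene. For the measured compounds named here, the one available step, from a dimethylphenyl to a benzothiophenyl, was small, which suggests this part of the molecule tolerates change of this kind, but it does not test this particular shift. The expectation is therefore a step of about a 1.2-fold higher number from compound 2 to compound 3 (0.06 log units; within the scatter) in this assay, that is, none beyond the scatter. For compound 3 the estimated value is 45 nM, with a range from 15 nM to 150 nM.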

Compound 3, half-maximal effective concentration: 180 nM
Estimate against measurement, compound 3: 4.0-fold (0.60 log units) below; the whole stated range lies below it.
By their numbers in this assay, from the lowest: compounds 1 and 2 (each within the scatter of the next); then compound 3.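

In this assay, this position proves sensitive to more than the kind of group it carries. 1-Benzothiophen-3-yl and 1-benzothiophen-5-yl have the same atoms and the same count of rings, donors and acceptors, yet changing only the point of attachment gives a 4.6-fold higher number from compound 2 to compound 3 (0.66 log units; beyond the scatter). The earlier pair suggested that this position accepted quite different aromatic groups, but that tolerance does not extend to every group, as replacing 2,6-dimethylphenyl with 1-benzothiophen-5-yl gives a 6.7-fold higher number from compound 1 to compound 3 (0.82 log units; beyond the scatter), whereas compound 2 remains within the scatter of compound 1. Nothing among the data shown explains why the point of attachment matters here.

Three compounds cannot show whether the higher number belongs to the 5-position attachment alone or to a wider group of attachment points, and 1-benzothiophen-2-yl, 1-benzothiophen-6-yl or naphthalen-2-yl would help to separate those possibilities. Going by these compounds, it also remains open whether a small addition to 1-benzothiophen-5-yl, such as a methyl or a fluorine, would move the number in either direction, or whether the same pattern would hold on a different core.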